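This account rests on a few compounds, and the source may have more. Where it says the series, first, only, none or still open, it means among the compounds named here.

Compound 1, `Cc1ccc(N(C)CC2CCC/C(=C\c3ccccc3)C2=O)cc1`, in a functional assay on the whole organism (Ear, strain Kunming) for inhibition, with Mus musculus as the target, with stated times of 1 h and 30 min, at a dose of 200 mg/kg by the oral route (on this read-out higher numbers stand for more inhibition at the one dose given (going by the name of the read-out) and lower numbers for less inhibition), gives 18.3%.
Compound 2, `Cc1ccc(/C=C2\CCCC(CN(C)c3ccc(C)cc3)C2=O)cc1`, gives 27.6%.
Compound 3, `CN(CC1CCC/C(=C\c2ccc(S(C)(=O)=O)cc2)C1=O)c1ccccc1`, gives 46.9%.

Among these three, compound 3 stands highest. Its value lies beyond the usual scatter above the next compound, compound 2 with 27.6%, and further still above compound 1 with 18.3%. Going by the values given here, no step is drawn between compound 3 and either of those two, so only the bare values can be set side by side.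

Compound 4, `Cc1ccc(N(C)CC2CCC/C(=C\c3ccc(S(C)(=O)=O)cc3)C2=O)cc1`, differs from compound 3 in one place: methyl in place of hydrogen on an aromatic carbon. The same kind of change has been measured once already, from compound 1 to compound 2, where the result was a number 9.3 percentage points higher from compound 1 to compound 2 (within the scatter), a shift that falls within the scatter of repeated measurements. Among the compounds with values here, that single comparison is the only guide here. Since it showed no clear movement, the same change on compound 3 is expected to leave the read-out essentially where it is, with an expected step of a number 3.1 percentage points higher from compound 3 to compound 4 (within the scatter), not beyond the scatter in either direction. On that basis compound 4 is estimated to give 50%, with an expected range from 36% to 64%.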

Compound 4, a percentage reported as inhibition, in the whole organism at one dose (the size of the read-out at that dose, not a potency): 27%
For compound 4 the middle estimate is 23 percentage points above the measured one, and the stated range ends above it.
By their numbers in this assay, from the lowest: compounds 1, 4 and 2 (each within the scatter of the next); then compound 3.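

In this assay, methyl in place of hydrogen on an aromatic carbon has no single effect that carries from one compound to another: the same change on two cores in this assay, a number 9.3 percentage points higher (within the scatter) from compound 1 to compound 2 and a number 19.9 percentage points lower (beyond the scatter) from compound 3 to compound 4, 29.2 percentage points apart, beyond the scatter of two such steps The two steps do not put the methyl in the same spot, since compound 1 already carries the methyl(4-methylphenyl)amino group and its step adds the methyl to the other phenyl, whereas a number 19.9 percentage points lower from compound 3 to compound 4 (beyond the scatter) comes from turning methyl(phenyl)amino into methyl(4-methylphenyl)amino in a compound that carries methylsulfonyl. With that methyl(4-methylphenyl)amino group in place, methylsulfonyl does not separate the compounds, as methylsulfonyl in place of hydrogen gives a number 8.7 percentage points higher from compound 1 to compound 4 (within the scatter), and methylsulfonyl in place of methyl gives a number 0.6 percentage points lower from compound 2 to compound 4 (within the scatter).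

Going by these compounds, it remains open whether a different group at this place, para to a large group, such as a chlorine atom or a methoxy group, would lower the number as methyl does. On these data alone, it is also open whether the pattern would hold with a group other than methylsulfonyl on the other phenyl, such as a carboxylic acid or an amine.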